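The source may hold more compounds than are shown below. What is called first, only, known or untested is meant among the compounds shown, and "the series" means these compounds.

Measured so far in an ADME assay on BJ cells (Homo sapiens) for cytotoxicity, read by CellTiter-Glo, with a stated time of 72 h; a higher number here means that more compound is needed for the effect, a lower number that less compound is needed:
compound 1 `CC1=C2CC(C)(C)/C=C/C(=O)/C(C)=C\C3=C[C@H](C)C[C@]3(O2)[C@]1(C)O` gives 26000 nM
compound 2 `C/C1=C/C2=C[C@H](C)C[C@@]23O[C@]2(CC(C)(C)[C@@H](Br)[C@@H]2C1=O)[C@](C)(Br)C3=O` gives 26000 nM
compound 3 `C/C1=C/C2=C[C@H](C)C[C@@]23O[C@]2(CC(C)(C)[C@@H](O)[C@@H]2C1=O)[C@@H](C)C3=O` gives 10400 nM

Compound 3 has the lowest number of the three, so less of it is needed for the effect. Compound 1 and compound 2 each stand higher by an amount beyond the usual scatter of repeated measurements.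

The next compound, compound 4 `CO[C@H]1[C@@H]2C(=O)/C(C)=C\C3=C[C@H](C)C[C@@]34O[C@]2(CC1(C)C)[C@@H](C)C4=O`, keeps the structure of compound 3 with a single change, hydroxy to methoxy, that is, methyl in place of hydrogen on an oxygen on a saturated carbon.

Within the data shown here, no two measured compounds differ in only one place, so the data offer no direct guide to the size of this step. In this assay no step beyond the scatter is expected. A slight lean towards a higher number is expected because compound 3 stands at 10400 nM, the lowest of the three. The estimated change is a 1.3-fold higher number from compound 3 to compound 4 (0.10 log units; within the scatter). For compound 4 the estimated value is 13000 nM, with an expected range of 5500 nM to 30000 nM.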

Compound 4, half-maximal effective concentration: 26000 nM
Compound 4: middle estimate off by 2.0-fold (0.30 log units), on the low side, within the range that was stated.
By their numbers in this assay, from the lowest: compound 3; then compounds 1, 2 and 4 (each within the scatter of the next).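

Among these compounds, putting methyl in place of hydrogen on the oxygen gives a 2.5-fold higher number from compound 3 to compound 4 (0.40 log units; beyond the scatter) in this assay, and this is the first single change that can be read on its own. It shows that the number responds to this small addition at this place: with the hydroxy group capped as methoxy, more compound is needed for the effect, and the advantage that set compound 3 apart is gone. Nothing available explains why the number moves in this direction.

The compounds shown leave open whether a longer chain such as ethyl on this oxygen, or an amine in place of the hydroxy group, would also raise the number. They also leave open whether the same step would have a similar size on a different core.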